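Fluoro for Methoxy in a Weak Trimethoxyphenyl Urea

A few compounds are considered here, and "the series" means these few. Any claim that something is new, unique, unknown or untested is made for them only; others in the source may bear on it.

Measured compounds:
compound 1, `COc1ccc(N(C)C(=O)N(C)c2cc(OC)c(OC)c(OC)c2)cc1`, >= 125000 nM
compound 2, `COc1ccc(C(=O)N(C)c2cc(OC)c(OC)c(OC)c2)cc1`, >= 125000 nM
compound 3, `COc1cc(NC(=O)c2ccc3ccccc3c2)cc(OC)c1OC`, 26800 nM

Of the compounds shown here, three have been tested in a functional assay on ONS-76 cells (Homo sapiens) for cytotoxicity, read by MTT assay, with a stated time of 72 h; a lower number here means a stronger inhibitor, a higher number a weaker inhibitor. Compound 1 `COc1ccc(N(C)C(=O)N(C)c2cc(OC)c(OC)c(OC)c2)cc1` reaches only the limit of the assay, giving >= 125000 nM, so no true number is known for it. Compound 2 `COc1ccc(C(=O)N(C)c2cc(OC)c(OC)c(OC)c2)cc1` likewise returns a limit, >= 125000 nM. Compound 3 `COc1cc(NC(=O)c2ccc3ccccc3c2)cc(OC)c1OC`, an amide rather than a urea, gives a measured value of 26800 nM. Compound 1 therefore stands at the weak end of what is shown, at the limit of >= 125000 nM in this assay, at which 2 of the 3 values shown sit. Within the data shown here, no step between two measured compounds that differ in a single place is available, so nothing yet tells how one small change moves this assay.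

Compound 4 `COc1cc(N(C)C(=O)N(C)c2ccc(F)cc2)cc(OC)c1OC` has not been measured. It differs from compound 1 by fluoro in place of methoxy on an aromatic carbon, para to a large group. With compound 1 known only as a limit, the starting point itself is uncertain. The expected step is an at least 1.2-fold lower number from compound 1 to compound 4 (0.09 log units; that floor lies within the scatter), nothing beyond the scatter. Compound 4 is estimated at 100000 nM, with a range from 30000 nM to 300000 nM, and it may again be reported as a limit only.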

Compound 4, half-maximal inhibitory concentration: >= 125000 nM
Compound 4: only a limit was reported; the forecaster's own chance of this, stated with the estimate: 60%; middle value at least 1.2-fold (0.09 log units) away from the limit.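

Compound 1 and compound 4 each return only a limit of the assay, so no step can be read between them: the limit of >= 125000 nM in this assay, at which 3 of the 4 values shown sit.

The compounds shown leave open whether fluoro in place of methoxy changes the true potency at all, and by how much.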